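Amide variation on the methylsulfonyl-bearing core

The source may report more compounds than this note shows. Statements on the series, on what has been measured and on what is new or still open speak of the compounds shown alone.

Compound 1 `CC(C)(NC(=O)COc1ccc2[nH]c(=O)c(-c3ccccn3)c(CCc3ccccc3)c2c1)c1ccccc1` gives 504 nM in a functional assay on CHO cells for antagonist activity at adenosine receptor A2b (Homo sapiens), read by cAMP accumulation, with stated times of 15 min and 1 h; a higher number here means a weaker inhibitor, a lower number a stronger inhibitor. Compound 2 `CC[C@H](NC(=O)COc1ccc2[nH]c(=O)c(-c3nccs3)c(CCc3ccccc3)c2c1)c1ccccc1` gives 7.4 nM in this assay. Compound 3 `CS(=O)(=O)c1c(CCc2ccccc2)c2cc(OCC(=O)NCC3CC3)ccc2[nH]c1=O` returns only a limit, > 5000 nM, in this assay. Compound 3 thus sits at the limit of > 5000 nM in this assay, at which 1 of the 3 values shown sits, the weak end of the numbers shown, with no measured number of its own. Compound 4 `CN(Cc1ccc(Cl)c(Cl)c1)C(=O)COc1ccc2[nH]c(=O)c(S(C)(=O)=O)c(CCc3ccccc3)c2c1` differs from compound 3 by (3,4-dichlorobenzyl)(methyl)amino in place of (cyclopropylmethyl)amino on a carbonyl carbon. Within the data shown here, no measured step covers this change. The expectation in this assay is a modest step toward stronger inhibition, possibly none beyond the scatter. Compound 4 is estimated at 3000 nM, within 500 nM to 20000 nM. The step of an at least 1.6-fold lower number from compound 3 to compound 4 (0.22 log units; that floor lies within the scatter) is an expectation only.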

Compound 4, inhibition constant: 1020 nM
Beside the measured number, compound 4's estimate is 2.9-fold (0.47 log units) above it; measured number inside the range.
By their numbers in this assay, from the lowest: compound 2; then compound 1; then compound 4. At a limit, above all of these: compound 3.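

Compound 3 remains a limit rather than a number: the limit of > 5000 nM in this assay, at which 1 of the 4 values shown sits.

On the methylsulfonyl-bearing core, (3,4-dichlorobenzyl)(methyl)amino in place of (cyclopropylmethyl)amino on a carbonyl carbon gives an at least 4.9-fold lower number from compound 3 to compound 4 (0.69 log units; beyond the scatter), so this place does respond to the amine part of the amide. The change alters the ring, the chlorines and the amide hydrogen together, and the compounds shown do not separate these. Open, from the compounds shown here alone, is whether a plain benzylamino group, or (3,4-dichlorobenzyl)amino without the methyl, would carry the same step.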